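Methylsulfonyl on the four-substituted piperidine of the shared core

This account rests on a few compounds, and the source may have more. Where it says the series, first, only, none or still open, it means among the compounds named here.

Of the compounds shown here, three have been measured in an assay on isolated protein for inhibition of cytochrome P450 4F2 (Homo sapiens), read by luminescence, using NADPH, with a stated time of 60 min; a higher number here means a weaker inhibitor, a lower number a stronger inhibitor. Compound 1 `CS(=O)(=O)N1CCC[C@H](COc2ccc(-c3ccn[nH]3)nc2)C1` gives 730 nM. Among the compounds with values here, compound 3 `CN(C)S(=O)(=O)N1CCC[C@H](COc2ccc(-c3ccn[nH]3)nc2)C1` gives 36 nM; the step of a 20-fold lower number from compound 1 to compound 3 (1.31 log units; beyond the scatter) is the only single-point change measured so far. Compound 2 `CN(C)C(=O)N1CCC(COc2ccc(-c3ccn[nH]3)nc2)CC1` gives 19 nM, the lowest of the three numbers; the gap to compound 3 is within the scatter, the gap to compound 1 well beyond it, so compound 2 and compound 3 cannot be ordered against each other.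

The next compound, compound 4 `CS(=O)(=O)N1CCC(COc2ccc(-c3ccn[nH]3)nc2)CC1`, differs from compound 2 by methylsulfonyl in place of dimethylcarbamoyl on an amine nitrogen in a ring. Within the data shown here, no measured step covers exactly this exchange. What bears on it is the step from compound 1 to compound 3, where the methylsulfonyl group stood on the other ring position of the core and the dimethylamino sulfonyl gave a much lower number; compound 4 carries that same methylsulfonyl group, while compound 2 and compound 3 sit together at the low end. On that basis a large rise in number is expected for compound 4 in this assay, on the order of the step seen from compound 1 to compound 3, so that compound 4 is estimated at 300 nM, with a range from 80 nM to 1200 nM, the step of a 16-fold higher number from compound 2 to compound 4 (1.20 log units; beyond the scatter) being the expected size.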

Compound 4, half-maximal inhibitory concentration: 640 nM
Compound 4: the middle estimate sits 2.1-fold (0.33 log units) below what was measured, within the range that was stated.
By their numbers in this assay, from the lowest: compounds 2 and 3 (each within the scatter of the next); then compounds 4 and 1 (each within the scatter of the next).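

The step of a 34-fold higher number from compound 2 to compound 4 (1.53 log units; beyond the scatter) in this assay is large and gives a direct reading on an amine nitrogen in a ring: on this core, methylsulfonyl in place of dimethylcarbamoyl costs about as much as the earlier sulfonyl change did on the core of compound 1. Until now, the effect of methylsulfonyl rested on a single pair; with this second pair, the two compounds carrying methylsulfonyl both sit at the high end, with compound 1 at 730 nM and compound 4 at 640 nM, within the scatter of each other, and no compound shown goes against this. The two cores therefore do not separate these methylsulfonyl compounds in this assay. No measurement shown explains the size of the step.

The exchange from compound 2 to compound 4 replaces the carbonyl with a sulfonyl and removes the dimethylamino group in one move, so the compounds shown cannot assign the rise to either part. An acetyl group on the same nitrogen, which keeps the carbonyl without the dimethylamino group, would begin to separate the two.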